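The compounds below may be only part of what the source reports. "The series", "measured", "known", "first", "only" and "open" are said of these compounds alone.

Measured so far:

compound 1, `CCOc1ccc(F)cc1C(C)NC(=O)NS(=O)(=O)c1ccc(C)cc1`: > 300000 nM
compound 2, `CCOc1ccc(Cl)cc1C(C)NC(=O)NS(=O)(=O)c1ccc(C)cc1`: > 300000 nM
compound 3, `CCOc1ccc(F)cc1C(C)NC(=O)N(C)S(=O)(=O)c1ccc(Cl)cc1`: 24500 nM

Of the compounds shown here, three have been tested in a functional assay on thoracic aorta (Rattus norvegicus, strain Wistar), with a stated time of 15 min; on this read-out higher numbers stand for an effect only at larger amounts of compound and lower numbers for an effect already at smaller amounts. For compound 1 the reading is a limit of the assay and not a number: compound 1 gives > 300000 nM. Compound 2 also stops at a limit: compound 2 gives > 300000 nM. Going by the values given here, compound 3 is the only one with a real number, since compound 3 gives 24500 nM in this assay.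

Compound 2 differs from compound 1 in a single place: chloro in place of fluoro on an aromatic carbon. Both readings sit at the limit of > 300000 nM in this assay, at which 2 of the 3 values shown sit, so the step that the two limits leave unreadable from compound 1 to compound 2 cannot be read; all that can be said is that neither compound reached an effect within the tested range. Compound 3 has a different core from compound 1, and the difference between the two cores is not broken down here.

Compound 4, `CCOc1ccc(Cl)cc1C(C)NC(=O)N(C)S(=O)(=O)c1ccc(Cl)cc1`, has not yet been measured in this assay. It differs from compound 3 by chloro in place of fluoro on an aromatic carbon, the same change made from compound 1 to compound 2. Since the earlier step is unreadable, there is no measured size to lean on, and the expected step of a 1.2-fold lower number from compound 3 to compound 4 (0.09 log units; within the scatter) is set near zero, resting on compound 3 at 24500 nM as the only available anchor. Compound 4 is therefore expected to give about 20000 nM in this assay. The estimated range for compound 4 runs from 5000 nM to 80000 nM.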

Compound 4, half-maximal effective concentration: 14600 nM
The estimate for compound 4 lay 1.4-fold (0.14 log units) above the measured number, within the range that was stated.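

Setting chloro in place of fluoro on the core that gives real numbers produces a 1.7-fold lower number from compound 3 to compound 4 (0.22 log units; within the scatter) in this assay, so on this core the change cannot be told apart from the ordinary variation between repeated measurements. The same change on the core of compound 1 cannot be read at all, since compound 1 and compound 2 both stop at a limit of the assay and not at a number: the limit of > 300000 nM in this assay, at which 2 of the 4 values shown sit.

Going by these compounds alone, that leaves only one readable step, with nothing measured to set beside it, so the data do not show whether the change behaves alike on the two cores, and a result on one core cannot be taken as a rule for the other.

Fluoro and chloro are the only groups shown on this aromatic carbon, so it stays open how a bromo group, a nitrile or an amine at the same place would read in this assay. Also open, as far as these compounds go, is whether a longer chain in place of the ethoxy group, such as a butoxy group, would give a real number on the core of compound 1 or shift the reading on the core of compound 3.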